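The source may report more compounds than this note shows. Statements on the series, on what has been measured and on what is new or still open speak of the compounds shown alone.

Of the compounds shown here, two have been measured in a functional assay on HEK293 cells for antagonist activity at Oxytocin receptor (Homo sapiens), read by calcium flux, with a stated time of 10 min, in the presence of a further agent that is not named here; a lower number here means a stronger inhibitor, a higher number a weaker inhibitor. Compound 1 `COCc1nnc(C2CCN(Cc3ccc(F)cc3Cl)CC2)n1-c1ccc(OC)nc1` gives 2790 nM. Compound 2 `CCOCc1nnc(N2C[C@@H]3C[C@]3(c3ccc(F)cc3Cl)C2)n1-c1ccc(OC)nc1` gives 9.3 nM, the lowest of the two numbers, and the gap between these two values is well beyond the scatter, though the structures differ in more than one place, so nothing is said about any single cause. Compound 3 `COc1ccc(-n2c(C3CC3)nnc2N2C[C@@H]3C[C@]3(c3ccc(F)cc3Cl)C2)cn1` is compound 2 with one change: cyclopropyl in place of ethoxymethyl on an aromatic carbon. Among the compounds with values here, no measured pair shows this change, so the expected step from compound 2 to compound 3 is a 1.7-fold higher number from compound 2 to compound 3 (0.24 log units; within the scatter), a small loss not clearly beyond the scatter. Compound 3 is estimated at 16 nM, within 4 nM to 65 nM.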

Compound 3, half-maximal inhibitory concentration: 433 nM
Estimate against measurement, compound 3: 27-fold (1.43 log units) below; the whole stated range lies below it.
By their numbers in this assay, from the lowest: compound 2; then compound 3; then compound 1.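

This carbon of the five-membered aromatic ring, between two ring nitrogen atoms, is sensitive to what it carries: cyclopropyl in place of ethoxymethyl gives a 47-fold higher number from compound 2 to compound 3 (1.67 log units; beyond the scatter), a large step beyond the scatter. The change is a small one on paper, yet it swaps an open chain holding an oxygen for a ring of carbon only. Nothing available explains the loss.

Since the oxygen and the ring change together, their contributions cannot be separated. A propyl group on this carbon, an open chain without oxygen, would be one way to pull them apart.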